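The compounds below may be only part of what the source reports. "The series", "measured", "known", "first", "only" and "open" are said of these compounds alone.

Going by the values given here, compound 1 `Oc1cccc(-c2cc(-c3ccsc3)cc(-c3cccc(O)c3)n2)c1` gives 16600 nM in a functional assay on HeLa cells (Homo sapiens) for cytotoxicity, read by CCK-8 assay (on this read-out higher numbers stand for weaker inhibition and lower numbers for stronger inhibition), the highest of the two numbers measured so far. Compound 2 `Oc1ccc(-c2cc(-c3ccsc3)cc(-c3cccc(O)c3)n2)cc1` gives 2580 nM in this assay. Among the compounds with values here, the step of a 6.4-fold lower number from compound 1 to compound 2 (0.81 log units; beyond the scatter) is the only measured step, and it changes a hydroxyphenyl group, not the part altered here. Compound 3 `Oc1cccc(-c2cc(-c3ccccn3)cc(-c3cccc(O)c3)n2)c1` differs from compound 1 by pyridin-2-yl in place of thiophen-3-yl on an aromatic carbon. Within the data shown here, no measured step bears on this change. Compound 3 is therefore expected to show no step beyond the scatter, a 1.1-fold lower number from compound 1 to compound 3 (0.04 log units; within the scatter). The estimate for compound 3 is 15000 nM, between 4000 nM and 50000 nM.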

Compound 3, half-maximal inhibitory concentration: 6500 nM
Compound 3: the middle estimate sits 2.3-fold (0.36 log units) above what was measured; measured number inside the range.
By their numbers in this assay, from the lowest: compound 2; then compound 3; then compound 1.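

The position opposite the ring nitrogen is not indifferent to what sits there: pyridin-2-yl in place of thiophen-3-yl gives a 2.6-fold lower number from compound 1 to compound 3 (0.41 log units; beyond the scatter). So this group, and not only the hydroxyphenyl groups, can shift the number in this assay. No measurement at hand explains the shift. Still open, as far as these compounds go, is whether an amine or a carboxylic acid at this position would lower the number further, and whether the same swap would have a similar effect on compound 2, which carries a 4-hydroxyphenyl group.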